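Cyclopropylsulfonyl Pyrrolidine Replaces Hydroxyacetyl on the Shared Core

The compounds below may be only part of what the source reports. "The series", "measured", "known", "first", "only" and "open" are said of these compounds alone.

Four compounds share one core and differ only in the group on an aromatic nitrogen. Compound 1 `CN1CCN(c2ccc(Nc3ncc4nc(Nc5ccc(F)cc5)n([C@H]5CCNC5)c4n3)cc2)CC1` is recorded in a functional assay on NCI-H1975 cells (Homo sapiens) for antiproliferative activity, read by MTT assay, with a stated time of 72 h (a higher number here means a weaker inhibitor, a lower number a stronger inhibitor), as "not determined" (no result reported). Compound 2 `CN1CCN(c2ccc(Nc3ncc4nc(Nc5ccc(F)cc5)n([C@H]5CCCN(S(=O)(=O)C6CC6)C5)c4n3)cc2)CC1`, which also carries a cyclopropylsulfonyl group, gives in this assay a value of 1150 nM. Compound 3 `CN1CCN(c2ccc(Nc3ncc4nc(Nc5ccc(F)cc5)n([C@@H]5CCN(C(=O)CO)C5)c4n3)cc2)CC1` carries the 1-((hydroxymethyl)carbonyl)pyrrolidin-3-yl group, and in this assay compound 3 is recorded as "not determined" (no result reported). Within the data shown here, compound 3 therefore stands without a number, and no step from it can be sized or given a direction beyond the scatter. Compound 4 `CN1CCN(c2ccc(Nc3ncc4nc(Nc5ccc(F)cc5)n([C@H]5CCN(S(=O)(=O)C6CC6)C5)c4n3)cc2)CC1` differs from compound 3 by 1-(cyclopropylsulfonyl)pyrrolidin-3-yl in place of 1-((hydroxymethyl)carbonyl)pyrrolidin-3-yl on an aromatic nitrogen. Because compound 2 gives 1150 nM with the same sulfonyl group, compound 4 is expected to land near that figure, at an estimated 900 nM within a range of 250 nM to 3500 nM.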

Compound 4, half-maximal inhibitory concentration: 580 nM
Estimate against measurement, compound 4: 1.6-fold (0.19 log units) above, and the stated range covers the measured number.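

In this assay, 1-(cyclopropylsulfonyl)pyrrolidin-3-yl in place of 1-(cyclopropylsulfonyl)piperidin-3-yl gives a 2.0-fold lower number from compound 2 to compound 4 (0.30 log units; within the scatter), so on this aromatic nitrogen the five-membered and six-membered rings are not told apart. Compound 3 has no number, and its step to compound 4 cannot be read. Nothing measured here accounts for the result. The compounds shown leave open whether a phenylsulfonyl group or a plain acetyl group on the pyrrolidine nitrogen would read the same as cyclopropylsulfonyl.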